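Swapping a ring amide for an open-chain amine

This account rests on a few compounds, and the source may have more. Where it says the series, first, only, none or still open, it means among the compounds named here.

Compound 1, `CS(=O)(=O)c1ccc(C(=O)NCCC(=O)N2CCCCC2)cc1[N+](=O)[O-]`, in an assay on isolated protein for inhibition of vitamin D3 receptor (Homo sapiens), read by fluorescence polarization (a lower number here means a stronger inhibitor, a higher number a weaker inhibitor), gives only a limit: compound 1 reads > 60000 nM.
Compound 2, `CS(=O)(=O)c1ccc(C(=O)NCCC(=O)N2CCCc3ccccc32)cc1[N+](=O)[O-]`, in this assay gives only a limit: compound 2 reads > 60000 nM.
Compound 3, `CC1CCN(C(=O)CCNC(=O)c2ccc(S(C)(=O)=O)c([N+](=O)[O-])c2)CC1`, in this assay gives only a limit: compound 3 reads > 60000 nM.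

Compound 3 cannot be placed above or below its two neighbours, as every value shown is a limit and not a number; the evidence is simply (the limit of > 60000 nM in this assay, at which 3 of the 3 values shown sit). The three measured steps, a step that the two limits leave unreadable from compound 1 to compound 2, a step that the two limits leave unreadable from compound 1 to compound 3 and a step that the two limits leave unreadable from compound 2 to compound 3, all leave their size unreadable for the same reason.

Compound 4, `CC(C)N(C(=O)CCNC(=O)c1ccc(S(C)(=O)=O)c([N+](=O)[O-])c1)C(C)C`, differs from compound 3 in one place: diisopropylamino in place of 4-methylpiperidin-1-yl on a carbonyl carbon. For the measured compounds named here, none of the measured steps gives a direction for this change, and nothing in the data points to a gain in inhibition. Compound 4 is therefore expected to stay at the limit, estimated at 80000 nM with a range from 30000 nM to 250000 nM. The expected step is a step that the limit leaves unreadable from compound 3 to compound 4, which is no change beyond the scatter.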

Compound 4, half-maximal inhibitory concentration: > 60000 nM
Compound 4 gave a limit, no number; the forecaster's own chance of this, stated with the estimate: 90%; the middle value is on the limit's open side.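

In this assay compound 4 reads > 60000 nM, which is a limit and not a number. Its steps from compound 1, compound 2 and compound 3 cannot be read, as every value shown is the same limit: the limit of > 60000 nM in this assay, at which 4 of the 4 values shown sit. The compounds shown leave open whether any group on this carbonyl carbon gives a measurable inhibition.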